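Swapping a Fluorophenyl Ring for Thiophene in a Cytotoxicity Series

A few compounds are considered here, and "the series" means these few. Any claim that something is new, unique, unknown or untested is made for them only; others in the source may bear on it.

Compound 1 `CCCc1n[nH]c2c(=O)n(NC(=O)c3ccncc3)c(-c3cccc(OC)c3)nc12`: 9.13%
Compound 2 `O=C(Nn1c(-c2cccc([N+](=O)[O-])c2)nc2c(-c3ccc(F)cc3)n[nH]c2c1=O)c1cccnc1`: 24.9%

Both numbers come from a functional assay on DU-145 cells (Homo sapiens) for cytotoxicity, read by sulforhodamine B assay, with a stated time of 2 days, tested at 100 uM; on this read-out higher numbers stand for more inhibition at the one concentration tested (going by the name of the read-out) and lower numbers for less inhibition. Compound 2 is the higher of the two, and compound 1 lies lower by a gap beyond the usual scatter; the two differ in several places at once, so no single change can be credited. Compound 3 `O=C(Nn1c(-c2cccc([N+](=O)[O-])c2)nc2c(-c3cccs3)n[nH]c2c1=O)c1cccnc1` keeps everything else of compound 2 and changes one group: thiophen-2-yl in place of 4-fluorophenyl on an aromatic carbon. For the measured compounds named here, no measured pair isolates such a swap, so the step of a number 2.9 percentage points lower from compound 2 to compound 3 (within the scatter) is expected to be small, with no direction favoured. Compound 3 is therefore estimated at 22%, within 8% to 40%.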

Compound 3, a percentage reported as inhibition, at one concentration (the size of the read-out at that concentration, not a potency): 32.8%
Compound 3: the middle estimate sits 10.8 percentage points below what was measured; low and high end bracket the measured number.
By their numbers in this assay, from the lowest: compound 1; then compounds 2 and 3 (each within the scatter of the next).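

In this assay this position on the five-membered aromatic ring can carry thiophen-2-yl in place of 4-fluorophenyl without a readable change (a number 7.9 percentage points higher from compound 2 to compound 3 (within the scatter)). A five-membered ring with one sulfur and a six-membered carbon ring therefore cannot be told apart here, at least with the other groups of compound 2 in place. No available measurement bears on why the two read alike.

Going by these compounds, whether an amine or a carboxylic acid at this position would give a change beyond the scatter remains open. So does whether this swap would read the same with different groups elsewhere on the shared core.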